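Thiourea in place of cyanoguanidine on a pyridazinone chain

The source may hold more compounds than are shown below. What is called first, only, known or untested is meant among the compounds shown, and "the series" means these compounds.

Compound 1 `C/N=C(/NC#N)NCCCn1nc(-c2ccccc2)ccc1=O` in a functional assay on the whole organism with Rattus norvegicus as the target; a higher number here means that more compound is needed for the effect, a lower number that less compound is needed: 78.1 mg/kg
Compound 2 `CC/N=C(/NC#N)NCCCCn1nc(-c2ccccc2)ccc1=O` in this assay: 60.7 mg/kg
Compound 3 `O=c1ccc(-c2ccccc2)nn1CCCCNC(=S)Nc1ccccc1` in this assay: > 100 mg/kg, a limit of the assay
Compound 4 `C=CCNC(=S)NCCCCn1nc(-c2ccccc2)ccc1=O`: not yet measured

Among the compounds with values here, only two numbers stand here. Compound 1 and compound 2 lie within the usual scatter of one another, so neither can be called the more potent. Compound 3 reaches only a limit, (the limit of > 100 mg/kg in this assay, at which 1 of the 3 values shown sits).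

Within the data shown here, the one measured step that touches the same part of the molecule is an at least 1.6-fold higher number from compound 2 to compound 3 (0.21 log units; that floor lies within the scatter), where a group of 9 heavy atoms (7 carbon, 1 nitrogen, 1 sulfur; one six-membered aromatic ring of carbon only) replaces a group of 7 heavy atoms (4 carbon, 3 nitrogen; no ring) on an amine nitrogen. The change to compound 4, (a group of 8 heavy atoms (5 carbon, 2 nitrogen, 1 sulfur; no ring) in place of a group of 7 heavy atoms (3 carbon, 4 nitrogen; no ring), on a saturated chain carbon, three bonds along the chain from an aromatic nitrogen), is of the same kind: nitrogen-rich group out, sulfur-bearing group in. Compound 4 is therefore expected to need more compound than compound 1, a step of a 1.4-fold higher number from compound 1 to compound 4 (0.15 log units; within the scatter), with a fair chance that only a limit is reported. Compound 4 is estimated at 110 mg/kg, within 60 mg/kg to 220 mg/kg.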

Compound 4, dose for half-maximal effect: 78.6 mg/kg
Estimate against measurement, compound 4: 1.4-fold (0.15 log units) above; low and high end bracket the measured number.
By their numbers in this assay, from the lowest: compounds 2, 1 and 4 (each within the scatter of the next). At a limit, above all of these: compound 3.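

In this assay, the thiourea bearing allyl proves no different from the cyanoguanidines, which the phenyl thiourea alone could not show: the exchange on a saturated chain carbon, three bonds along the chain from an aromatic nitrogen, gives a 1.0-fold higher number from compound 1 to compound 4 (0.00 log units; within the scatter), and the exchange on an amine nitrogen gives a 1.3-fold higher number from compound 2 to compound 4 (0.11 log units; within the scatter). Compound 3 stands only at a limit of the assay: the limit of > 100 mg/kg in this assay, at which 1 of the 4 values shown sits.
With allyl in place of phenyl on an amide-type nitrogen, the step reads an at least 1.2-fold lower number from compound 3 to compound 4 (0.10 log units; that floor lies within the scatter), so it gives only a floor and does not separate the two groups.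

From the compounds shown here alone, how far allyl and phenyl truly differ therefore stays open. The compounds shown also do not tell how a urea, a benzyl group or a cyclopropyl group in this place would read in this assay.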